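The source may hold more compounds than are shown below. What is called first, only, known or untested is meant among the compounds shown, and "the series" means these compounds.

Of the compounds shown here, two built on one shared core have so far been measured in a functional assay on DU-145 cells (Homo sapiens) for cytotoxicity, read by sulforhodamine B assay, with a stated time of 48 h; on this read-out higher numbers stand for weaker inhibition and lower numbers for stronger inhibition. Compound 1 `COc1ccc(C2=NO[C@]3(C2)C(=O)O[C@@H]2[C@H]3CC[C@H](C)[C@]3(O)C=CC(=O)[C@@]23C)cc1`, with methoxy on an aromatic carbon, gives 20000 nM. Compound 2 `C[C@H]1CC[C@@H]2[C@@H](OC(=O)[C@]23CC(c2ccc([N+](=O)[O-])cc2)=NO3)[C@]2(C)C(=O)C=C[C@@]12O`, with nitro at that carbon, gives 7000 nM, the lower of the two numbers and so the stronger inhibition so far. Compound 3 `C[C@H]1CC[C@@H]2[C@@H](OC(=O)[C@]23CC(c2ccccc2Cl)=NO3)[C@]2(C)C(=O)C=C[C@@]12O` has not yet been measured. It differs from compound 2 in one place, on a carbon with a double bond to nitrogen: 2-chlorophenyl in place of 4-nitrophenyl on a carbon with a double bond to nitrogen. For the measured compounds named here, only one measured step bears on this change, a 2.9-fold lower number from compound 1 to compound 2 (0.46 log units; beyond the scatter), which is modest and came from putting nitro in place of methoxy. That step changed a single group on the aromatic ring, whereas here the whole 4-nitrophenyl is replaced, so it offers only a loose guide. Compound 3 also lacks the nitro, so a small move towards a higher number in this assay is expected, though it may stay within the scatter. The expected step is a 1.6-fold higher number from compound 2 to compound 3 (0.20 log units; within the scatter). For compound 3 the estimated value is 11000 nM, with an expected range from 4000 nM to 30000 nM.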

Compound 3, half-maximal inhibitory concentration: 19000 nM
Estimate against measurement, compound 3: 1.7-fold (0.24 log units) below; the measured number falls inside the stated range.
By their numbers in this assay, from the lowest: compound 2; then compounds 3 and 1 (each within the scatter of the next).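

The new result shows that the gain seen with compound 2 does not carry over to another aromatic group at this carbon, next to the ring nitrogen: in this assay there is a 2.7-fold higher number from compound 2 to compound 3 (0.43 log units; beyond the scatter), a step larger than the estimate allowed for, while the change from 4-methoxyphenyl to 2-chlorophenyl gives a 1.1-fold lower number from compound 1 to compound 3 (0.02 log units; within the scatter), so those two groups cannot be told apart here. Among these three compounds, then, 4-nitrophenyl alone stands apart as the strongest, and a chlorine on the ring does nothing measurable to close the gap to it, though a single nitro example is a thin basis for any trend. No experimental evidence is given that would explain why the nitro compound differs from the other two.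

Going by these compounds, what stays open is whether the difference belongs to the nitro group itself or to where a group sits on the phenyl ring, since 2-chlorophenyl and 4-nitrophenyl differ in both. On these data alone, it is also open how an amine or a carboxylic acid on that ring would behave, or a longer alkyl chain in place of the whole aromatic group.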